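This account rests on a few compounds, and the source may have more. Where it says the series, first, only, none or still open, it means among the compounds named here.

Compound 1 `CC(O)(C(=O)Nc1ccc(S(=O)(=O)c2ccccc2C#N)cc1)C(F)(F)F` is a sulfonyl-linked anilide carrying a hydroxy-trifluoromethyl amide, and in a functional assay (Cavia porcellus) with sulfonylurea receptors; K-ATP channels (Homo sapiens) as the target (on this read-out lower numbers stand for stronger inhibition and higher numbers for weaker inhibition), compound 1 gives 1100 nM, the lower of the two numbers recorded. Compound 2 `CC(O)(C(=O)Nc1ccc(S(=O)(=O)c2ccccc2)c(Cl)c1)C(F)(F)F` in this assay gives 2200 nM, and the two values sit within the scatter of each other, so neither can be called stronger. Compound 3 `Cc1ccccc1S(=O)(=O)c1ccc(NC(=O)C(C)(O)C(F)(F)F)cc1` is unmeasured; it differs from compound 1 by methyl in place of cyano on an aromatic carbon. Within the data shown here, with no comparable step recorded, only a modest change is expected, perhaps a little toward weaker inhibition, so the step from compound 1 is estimated as a 1.6-fold higher number from compound 1 to compound 3 (0.21 log units; within the scatter). Compound 3 is therefore estimated at 1800 nM, expected between 600 nM and 5500 nM.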

Compound 3, half-maximal inhibitory concentration: 5100 nM
Estimate against measurement, compound 3: 2.8-fold (0.45 log units) below, within the range that was stated.
By their numbers in this assay, from the lowest: compounds 1 and 2 (each within the scatter of the next); then compound 3.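

Replacing cyano with methyl at this place, on an aromatic carbon ortho to a large group, gives a 4.6-fold higher number from compound 1 to compound 3 (0.67 log units; beyond the scatter) in this assay. This is the first single-place comparison shown, and it establishes that the group here can shift the number beyond the scatter, which compounds 1 and 2, differing in more than one place, could not show. No measurement shown explains the shift.

Still open, on these data alone, is whether an amine, a methoxy group or a carboxylic acid at this place would give a number nearer compound 1 or compound 3.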